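Compound 3 and the untested change on the carbonyl carbon

A few compounds are considered here, and "the series" means these few. Any claim that something is new, unique, unknown or untested is made for them only; others in the source may bear on it.

Measured in an ADME assay on microsomes from liver (Mus musculus) for metabolic stability; a lower number here means that the compound disappears faster, a higher number that the compound lasts longer
compound 1 `NS(=O)(=O)CC(=O)NCCSc1nonc1/C(=N/O)Nc1cccc(C(F)F)c1` gives 1.5 h
compound 2 `NS(=O)(=O)CC(=O)NCCSc1nonc1/C(=N/O)Nc1cccc(Cl)c1` gives 1.26 h
compound 3 `NS(=O)(=O)CC(=O)NCCSc1nonc1/C(=N/O)Nc1ccc(F)c(C(F)F)c1` gives 1.07 h

Compound 3 at 1.07 h sits within the scatter of both other compounds. The three measured steps are a 1.2-fold lower number from compound 1 to compound 2 (0.08 log units; within the scatter) and a 1.4-fold lower number from compound 1 to compound 3 (0.15 log units; within the scatter) and a 1.2-fold lower number from compound 2 to compound 3 (0.07 log units; within the scatter) and all three lie within the scatter. Each alters only the aromatic substituents, and none touches the group on the carbonyl carbon.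

Compound 4 `CC1(C(=O)NCCSc2nonc2/C(=N/O)Nc2ccc(F)c(C(F)F)c2)CCN1` differs from compound 3 at exactly that untested place: a group of 5 heavy atoms (4 carbon, 1 nitrogen; one four-membered non-aromatic ring with 1 hetero atom) in place of a group of 5 heavy atoms (1 carbon, 1 nitrogen, 2 oxygen, 1 sulfur; no ring), on a carbonyl carbon is the change. The series therefore gives no direct size for this step. Among the compounds with values here, with no measured precedent for the new group, and with the step to compound 3 as small as a 1.4-fold lower number from compound 1 to compound 3 (0.15 log units; within the scatter) for an unrelated change, no shift beyond the scatter in this assay is expected, though with low confidence. The estimated step is a 1.1-fold lower number from compound 3 to compound 4 (0.03 log units; within the scatter) and it carries a wide margin. For compound 4 the expected half-life is 1 h with an estimated range from 0.4 h to 2.2 h in this measurement.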

Compound 4, half-life: 0.268 h
Estimate against measurement, compound 4: 3.7-fold (0.57 log units) above; the whole stated range lies above it.
By their numbers in this assay, from the lowest: compound 4; then compounds 3, 2 and 1 (each within the scatter of the next).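

In this assay the group on the carbonyl carbon proves to be a place where one change reaches beyond the scatter, with a 4.0-fold lower number from compound 3 to compound 4 (0.60 log units; beyond the scatter) on replacing sulfamoylmethyl by the group with the four-membered non-aromatic ring, while the aromatic changes among compound 1, compound 2 and compound 3 all stay within it. This rests on a single pair, in which atom types, ring content and hydrogen-bond acceptor count all change at once. Nothing available gives a cause for this step.

Going by these compounds, whether the drop follows the ring, its nitrogen or the loss of sulfamoylmethyl stays open. An open-chain amine, a carboxylic acid or a plain methyl on the carbonyl carbon would help separate these, and the same exchange on compound 1 or compound 2 would test whether the step carries over.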